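A few compounds are considered here, and "the series" means these few. Any claim that something is new, unique, unknown or untested is made for them only; others in the source may bear on it.

Of the compounds shown here, three have been tested in a functional assay on WiDr cells (Homo sapiens) for inhibition, read by sulforhodamine B assay, with a stated time of 48 h; a higher number here means a weaker inhibitor of growth, a lower number a stronger inhibitor of growth. Compound 1 (`O=C(CCC(F)(F)C(F)(F)C(F)(F)C(F)(F)C(F)(F)C(F)(F)C(F)(F)C(F)(F)F)NCCCCCCCCCN[C@@H]1[C@H](O)[C@@H](O)[C@H](O)[C@H]2COC(=O)N21`) gives > 100000 nM, which is a limit of the assay. Compound 2 (`O=C(CCC(F)(F)C(F)(F)C(F)(F)C(F)(F)F)NCCCCCCCCCN[C@@H]1[C@H](O)[C@@H](O)[C@@H](O)[C@H]2COC(=O)N21`) gives > 100000 nM, again a limit. Going by the values given here, compound 3 (`O=C(CCC(F)(F)C(F)(F)C(F)(F)C(F)(F)C(F)(F)C(F)(F)F)NCCCCCCCCCN[C@@H]1[C@H](O)[C@@H](O)[C@@H](O)[C@H]2COC(=O)N21`) gives 17000 nM, the only actual number in the set, while the limit of > 100000 nM in this assay, at which 2 of the 3 values shown sit, marks where the other two results sit.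

Compound 4 (`O=C(CCC(F)(F)C(F)(F)C(F)(F)C(F)(F)C(F)(F)C(F)(F)C(F)(F)C(F)(F)F)NCCCCCCCCCN[C@@H]1[C@H](O)[C@@H](O)[C@@H](O)[C@H]2COC(=O)N21`) follows from compound 3 by a single change in the fluorinated chain: 1,1,2,2,2-pentafluoroethyl in place of fluoro on a saturated chain carbon bound to two fluorine atoms and a saturated chain carbon. The same exchange has been measured once, as an at least 5.8-fold lower number from compound 2 to compound 3 (0.76 log units; beyond the scatter). That single step starts from a limit, so it gives only a lower bound on the size of the change and no exact figure. It nevertheless points towards a lower number in this assay, and a further step of modest size is expected in that direction. The expected change is a 1.9-fold lower number from compound 3 to compound 4 (0.28 log units; within the scatter), though one earlier step is thin support. For compound 4 the estimated value is 9000 nM, with an expected range of 2500 nM to 40000 nM.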

Compound 4, concentration for 50% growth inhibition: > 100000 nM
Compound 4 was reported as a limit; the forecaster's own chance of this, stated with the estimate: 15%; middle value at least 11-fold (1.04 log units) from the limit.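

In this assay, the exchange of fluoro for 1,1,2,2,2-pentafluoroethyl on a saturated chain carbon bound to two fluorine atoms and a saturated chain carbon does not hold one direction: it now gives an at least 5.8-fold higher number from compound 3 to compound 4 (0.76 log units; beyond the scatter), against an at least 5.8-fold lower number from compound 2 to compound 3 (0.76 log units; beyond the scatter) at its earlier appearance. Going by these compounds alone, compound 3 therefore stands alone as the only compound with a number, and the other results rest at a limit: the limit of > 100000 nM in this assay, at which 3 of the 4 values shown sit. Within the data shown here, the steps between two limits cannot be read, so changing the configuration at a saturated ring carbon shows no readable effect here, and the one structural fact this pair offers is: the fact that compounds 1 and 4 differ only in the configuration as drawn.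

Going by these compounds, how far compound 2 and compound 4 lie beyond the limit remains open. So does whether a plain alkyl chain or a carboxylic acid in place of the fluorinated chain would give a number in this assay.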